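Carboxycyclopropyl to Carbamoylethyl: Forecasting the Maximal Response

The source may hold more compounds than are shown below. What is called first, only, known or untested is meant among the compounds shown, and "the series" means these compounds.

Compound 2 `O=C(O)[C@@H]1C[C@H]1c1ccc(NCc2cccc(Oc3ccccc3)c2)cc1` is the weaker of the two measured compounds in a functional assay on CHO cells for agonist activity at Free fatty acid receptor 1 (Homo sapiens), read by a luciferase reporter (on this read-out higher numbers stand for larger maximal responses and lower numbers for smaller maximal responses), where compound 2 gives 64%. Among the compounds with values here, its only measured neighbour, compound 1 `CC(CC(=O)O)c1ccc(NCc2cccc(Oc3ccccc3)c2)cc1`, gives 83% in this assay, and the single recorded step, a number 19 percentage points lower from compound 1 to compound 2 (beyond the scatter), is the only guide to how changes at this position move the read-out. Compound 3 `NC(=O)CCc1ccc(NCc2cccc(Oc3ccccc3)c2)cc1` differs from compound 2 by 2-carbamoylethyl in place of 2-carboxycyclopropyl on an aromatic carbon. Within the data shown here, no measured step covers the exchange of a 2-carboxycyclopropyl group for a 2-carbamoylethyl chain; the one step available kept a carboxy-bearing side chain in place and changed only its shape, and that step was modest in size and downward. How much further the maximal response moves once the carboxy group itself is gone cannot be read from the two numbers, so the forecast carries wide uncertainty. Compound 3 is nevertheless expected to fall below compound 2, with an estimated step of a number 24 percentage points lower from compound 2 to compound 3 (beyond the scatter). The estimate for compound 3 is 40%, with a range from 10% to 70%.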

Compound 3, largest response reached (reported as percent of maximum), in percent of the reference or control that the assay uses: 68%
The estimate for compound 3 lay 28 percentage points below the measured number; the range from low to high includes it.
By their numbers in this assay, from the lowest: compounds 2 and 3 (each within the scatter of the next); then compound 1.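

In this assay, the exchange of 2-carboxycyclopropyl for 2-carbamoylethyl on this aromatic carbon gives [ a number 4 percentage points higher from compound 2 to compound 3 (within the scatter) ], so in this pair the carboxy group, the three-membered ring and both defined stereocentres can leave together without a change beyond the scatter. Among the compounds shown, then, a sizeable maximal response does not depend on a carboxy group at this position, although the side chain still counts: the comparison with the 1-(carboxymethyl)ethyl group gives [ a number 15 percentage points lower from compound 1 to compound 3 (beyond the scatter) ], which leaves compound 1 apart from compound 3 as well as from compound 2. Nothing measured here accounts for these results.

The compounds shown change several features at once, so a 2-carbamoylcyclopropyl group or an unbranched 2-carboxyethyl group would be needed to separate the contribution of the end group from that of the chain's shape. From the compounds shown here alone, how a sulfonamide or a hydroxyl at the end of the chain, or a longer chain bearing the same carbamoyl group, would fare at this position also remains open.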